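The source may report more compounds than this note shows. Statements on the series, on what has been measured and on what is new or still open speak of the compounds shown alone.

In a functional assay on HL-60 cells (Homo sapiens) for inhibition, read by CCK-8 assay, with a stated time of 48 h, tested at 20 uM (a higher number here means more inhibition of growth at the concentration tested, a lower number less inhibition of growth), compound 2 (`N#C/C(=C\c1ccccc1OS(=O)(=O)c1ccc(Cl)cc1)C(=O)Nc1nnc(Cc2ccccc2)s1`) gives 26%, compound 1 (`Cc1ccc(S(=O)(=O)Oc2ccccc2/C=C(\C#N)C(=O)Nc2nnc(Cc3ccccc3)s2)cc1`) gives 16% and compound 3 (`N#C/C(=C\c1ccccc1OS(=O)(=O)c1ccc(F)cc1)C(=O)Nc1nnc(Cc2ccccc2)s1`) gives 22%, so compound 2 is not separated from either of the others. Compound 4 (`N#C/C(=C\c1ccccc1OS(=O)(=O)c1ccc(Cl)cc1)C(=O)Nc1nnc(Cc2ccc(F)cc2)s1`) differs from compound 2 in one place: fluoro in place of hydrogen on an aromatic carbon. This is fluoro in place of hydrogen on an aromatic carbon, which turns benzyl to 4-fluorobenzyl. The three measured steps bear on this only indirectly, since each exchanges a group elsewhere in the molecule and none touches the benzyl group. Chloro in place of methyl gave a number 10 percentage points higher from compound 1 to compound 2 (within the scatter), fluoro in place of methyl gave a number 6 percentage points higher from compound 1 to compound 3 (within the scatter), and fluoro in place of chloro gave a number 4 percentage points lower from compound 2 to compound 3 (within the scatter). Among the measured compounds shown here, all of these stayed within the scatter, and no measured compound carries a substituent on the benzyl group, so the data hold no direct precedent. No step beyond the scatter is therefore expected in this assay. The estimated move is a number 2 percentage points higher from compound 2 to compound 4 (within the scatter). Compound 4 is expected at 28%, with an estimated range of 15% to 45%.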

Compound 4, percent growth inhibition at one concentration: 20%
The estimate for compound 4 lay 8 percentage points above the measured number; the measured number falls inside the stated range.
By their numbers in this assay, from the lowest: compounds 1, 4, 3 and 2 (each within the scatter of the next).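

Among the compounds shown here, this is the first change at the benzyl group: in this assay, fluoro in place of hydrogen gives a number 6 percentage points lower from compound 2 to compound 4 (within the scatter), so a fluoro on this six-membered aromatic ring, para to a large group, produces no step that stands out from the scatter. The earlier steps shown here all lay elsewhere in the molecule and said nothing about this position, which now has a single reading that does not separate 4-fluorobenzyl from benzyl. Nothing available bears on the cause of this step.

On these data alone, it remains open whether a chloro, a methoxy or an amine at the same place on the ring would give a step beyond the scatter. As far as these compounds go, it is equally open whether a longer chain or a carboxylic acid in place of the benzyl group would do so.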